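Benzylcarbamoyl to Benzoyl on the Chain Terminus

The source may hold more compounds than are shown below. What is called first, only, known or untested is meant among the compounds shown, and "the series" means these compounds.

For the measured compounds named here, compound 2 `CCOC(=O)C1CCCN(Cc2cn(CC(O)COC(=O)NCc3ccccc3)nn2)C1` stands highest of the two numbers so far: in an assay on nucleic acid for inhibition of Nucleic Acid, read by fluorescence, tested at 100 uM (a higher number here means more inhibition at the concentration tested (going by the name of the read-out), a lower number less inhibition), compound 2 gives 47%, while compound 1 `CCCCNC(=O)OCC(O)Cn1cc(CN2CCCC(C(=O)OCC)C2)nn1` gives 24%. Going by the values given here, the single measured step, a number 23 percentage points higher from compound 1 to compound 2 (beyond the scatter), altered the group on the saturated chain carbon bound to the amide-type nitrogen. Compound 3 `CCOC(=O)C1CCCN(Cc2cn(CC(O)COC(=O)c3ccccc3)nn2)C1` differs from compound 2 by phenyl in place of benzylamino on a carbonyl carbon, that is benzylcarbamoyl to benzoyl. Among the compounds with values here, no measured step touches the carbonyl carbon, so that step gives no direct guide here. With nothing to set a direction, compound 3 is expected to stay within scatter, a step of a number 5 percentage points lower from compound 2 to compound 3 (within the scatter). The estimate for compound 3 in this assay is 42%, with a range from 22% to 62%.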

Compound 3, a percentage reported as inhibition, at one concentration (the size of the read-out at that concentration, not a potency): 6%
For compound 3 the middle estimate is 36 percentage points above the measured one; measured number below the stated range.
By their numbers in this assay, from the lowest: compound 3; then compound 1; then compound 2.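

In this assay the carbonyl carbon proves sensitive to what it carries: phenyl in place of benzylamino gives a number 41 percentage points lower from compound 2 to compound 3 (beyond the scatter) and phenyl in place of butylamino gives a number 18 percentage points lower from compound 1 to compound 3 (beyond the scatter). Compound 3 thus falls below both carbamoyl compounds, and the earlier phenyl-for-propyl gain does not carry over to a benzoyl group. No measurement here accounts for the drop.

On these data alone, it remains open whether the loss follows the amide nitrogen with its hydrogen or the shorter group as a whole. A phenylacetyl group in place of benzylcarbamoyl would separate the two.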